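The source may report more compounds than this note shows. Statements on the series, on what has been measured and on what is new or still open speak of the compounds shown alone.

Working notes on the series. The shared core is common to compound 1 `c1ccc(-c2cn3ccnc3c(-c3ccc4ncn(C5CCCCC5)c4c3)n2)cc1`, compound 2 `Fc1ccc(-c2cn3ccnc3c(-c3ccc4ncn(C5CCCCC5)c4c3)n2)cc1` and compound 3 `CC(=O)c1ccc(-c2cn3ccnc3c(-c3ccc4ncn(C5CCCCC5)c4c3)n2)cc1`; they differ only in what sits on the outer six-membered carbon ring. In a functional assay on UO-31 cells (Homo sapiens) for inhibition, read by sulforhodamine B assay, with a stated time of 48 h, tested at 10 uM (a higher number here means more inhibition at the concentration tested (going by the name of the read-out), a lower number less inhibition), compound 1 gives 55.2%, compound 2 gives 37.8% and compound 3 gives 23.1%. Compound 1 thus stands highest of the three, with compound 2 nearest and compound 3 furthest.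

Both measured exchanges of hydrogen on that ring moved the read-out down: a number 17.4 percentage points lower from compound 1 to compound 2 (beyond the scatter) and a number 32.1 percentage points lower from compound 1 to compound 3 (beyond the scatter); between the two substituted compounds a number 14.7 percentage points lower from compound 2 to compound 3 (beyond the scatter).

Compound 4 `COc1ccccc1-c1cn2ccnc2c(-c2ccc3ncn(C4CCCCC4)c3c2)n1` is the next point. Relative to compound 1 the change is methoxy in place of hydrogen on an aromatic carbon. The steps from compound 1 to compound 2 and from compound 1 to compound 3 bear on it, both modest to large and downward, so a downward step beyond the scatter is expected here too, though the entering group and its place on the ring differ from both measured cases. For compound 4 the estimate in this assay is 40%, with a range of 22% to 58%, meaning an expected step of a number 15.2 percentage points lower from compound 1 to compound 4 (beyond the scatter).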

Compound 4, a percentage reported as inhibition, at one concentration (the size of the read-out at that concentration, not a potency): 24%
Estimate against measurement, compound 4: 16 percentage points above; measured number inside the range.
By their numbers in this assay, from the lowest: compounds 3 and 4 (each within the scatter of the next); then compound 2; then compound 1.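

Methoxy ortho to a large group gives a large fall (a number 31.2 percentage points lower from compound 1 to compound 4 (beyond the scatter)), so in this assay a third entering group, at a different place on the outer ring, also reads below the unsubstituted compound 1, which stays highest of the four. Against the other substituted compounds, the change to 2-methoxyphenyl shows no separation from 4-acetylphenyl (a number 0.9 percentage points higher from compound 3 to compound 4 (within the scatter)) but a clear gap from 4-fluorophenyl (a number 13.8 percentage points lower from compound 2 to compound 4 (beyond the scatter)), so the three substituted compounds do not share one level, and the size of the fall depends on the group, its place or both. No measurement shown here accounts for these falls.

Group and place change together in these compounds, so what each contributes stays open, including how 4-methoxyphenyl would read. Going by these compounds, how an amine or a carboxylic acid on this ring would read also remains open.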